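The compounds below may be only part of what the source reports. "The series", "measured", "known", "first", "only" and "open" are said of these compounds alone.

In a functional assay on cells (KATO III cell, Homo sapiens) for antiproliferative activity, read by MTT assay (a lower number here means a stronger inhibitor, a higher number a weaker inhibitor), compound 1 `O=C1NC(c2ccccc2)CN1S(=O)(=O)c1ccc2c(c1)CCCN2` gives only a limit, > 20000 nM. For the measured compounds named here, compound 2 `COC(=O)N1CCCc2cc(S(=O)(=O)N3CC(c4ccccc4)NC3=O)ccc21`, with methoxycarbonyl in place of hydrogen on a nitrogen, reads 16500 nM, the only true number so far. Compound 3 `CCOC(=O)N1CCCc2cc(S(=O)(=O)N3CC(c4ccccc4)NC3=O)ccc21` differs from compound 2 by methyl in place of hydrogen on a saturated chain carbon bound to an oxygen next to a carbonyl group, which turns methoxycarbonyl to ethoxycarbonyl. Going by the values given here, the only measured step, an at least 1.2-fold lower number from compound 1 to compound 2 (0.08 log units; that floor lies within the scatter), rests on that limit, stays within the scatter and concerns another change, so no step beyond the scatter is expected in this assay. The expected step is a 1.1-fold lower number from compound 2 to compound 3 (0.04 log units; within the scatter). For compound 3 the estimated value is 15000 nM, with an expected range of 8000 nM to 26000 nM.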

Compound 3, half-maximal inhibitory concentration: 11200 nM
Estimate against measurement, compound 3: 1.3-fold (0.13 log units) above; the range from low to high includes it.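

Ethoxycarbonyl in place of methoxycarbonyl gives a 1.5-fold lower number from compound 2 to compound 3 (0.17 log units; within the scatter) in this assay, so this added methyl, on a saturated chain carbon bound to an oxygen next to a carbonyl group, leaves the reading within the scatter. The ethoxycarbonyl group as a whole gives an at least 1.7-fold lower number from compound 1 to compound 3 (0.25 log units; that floor lies within the scatter) and that floor also lies within the scatter. That step rests on a limit for compound 1, not a number: the limit of > 20000 nM in this assay, at which 1 of the 3 values shown sits.

Going by these compounds, whether a longer chain, such as propoxycarbonyl, or a benzyloxycarbonyl group at this place would give a step beyond the scatter stays open.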